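This account rests on a few compounds, and the source may have more. Where it says the series, first, only, none or still open, it means among the compounds named here.

Measured so far, in a functional assay on PC-3 cells (Homo sapiens) for cytotoxicity, read by MTT assay, with a stated time of 72 h; on this read-out lower numbers stand for stronger inhibition and higher numbers for weaker inhibition:

compound 1 `CCCOCNc1n[n+]([O-])c2cc(OC)ccc2[n+]1[O-]`: 10600 nM
compound 2 `[O-][n+]1nc(NCOCc2ccc(C(F)(F)F)cc2)[n+]([O-])c2ccccc21`: 9310 nM
compound 3 `CCCOCNc1n[n+]([O-])c2ccccc2[n+]1[O-]`: 7400 nM

Among the compounds with values here, compound 1 gives the highest of the three numbers in this assay, but its gap to compound 2 is within the scatter, and the one single-point step from it, a 1.4-fold lower number from compound 1 to compound 3 (0.16 log units; within the scatter), is also within the scatter. No ordering among the three is therefore established.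

Compound 4 `CCCCCOCNc1n[n+]([O-])c2cc(OC)ccc2[n+]1[O-]` is not yet measured. It differs from compound 1 by ethyl in place of hydrogen on a saturated chain carbon, three bonds along the chain from an oxygen on a saturated carbon. Within the data shown here, no measured step covers a change of this kind: the only step on record, a 1.4-fold lower number from compound 1 to compound 3 (0.16 log units; within the scatter), concerns the methoxy on an aromatic carbon and not the chain, and compound 2 differs from compound 1 in more than one place, so its value bears only loosely. With no step beyond the scatter anywhere in the series, the expectation for compound 4 in this assay is a 1.1-fold lower number from compound 1 to compound 4 (0.05 log units; within the scatter), that is, no change beyond the scatter. Compound 4 is estimated at 9500 nM, with a range from 4500 nM to 20000 nM.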

Compound 4, half-maximal inhibitory concentration: 30900 nM
Estimate against measurement, compound 4: 3.3-fold (0.51 log units) below; the measured number lies above the stated range.
By their numbers in this assay, from the lowest: compounds 3, 2 and 1 (each within the scatter of the next); then compound 4.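

In this assay, the saturated chain carbon three bonds along the chain from an oxygen on a saturated carbon is the one place in the series where a single change moves the number beyond the scatter: ethyl in place of hydrogen gives a 2.9-fold higher number from compound 1 to compound 4 (0.46 log units; beyond the scatter) and so points toward weaker inhibition. Within the data shown here, on the core of compound 1, this position therefore responds to the propyl to pentyl change, whereas the only earlier step, at the aromatic methoxy, stayed within the scatter. Nothing measured here accounts for the shift, so its origin remains unassigned.

As far as these compounds go, whether a longer chain continues in the same direction, or an amine or a carboxylic acid on this chain carbon behaves differently, remains open. Also open, from the compounds shown here alone, is whether the same ethyl change gives a similar step on compound 3, which lacks the methoxy.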